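Taking the Nitro Group off Compound 2

The source may hold more compounds than are shown below. What is called first, only, known or untested is meant among the compounds shown, and "the series" means these compounds.

In a functional assay on HepG2 cells (Homo sapiens) for antiproliferative activity, read by fluorescence and resazurin assay, with a stated time of 48 h (a lower number here means a stronger inhibitor, a higher number a weaker inhibitor), two compounds sharing one core have been measured. Compound 1 `O=C(N/N=C/c1ccncc1)c1cc2cc(Br)ccc2oc1=O`, which carries bromo, gives 4890 nM, and compound 2 `O=C(N/N=C/c1ccncc1)c1cc2cc([N+](=O)[O-])ccc2oc1=O`, which carries nitro, gives 15800 nM. Compound 2 therefore holds the higher of the two numbers, making it the weaker inhibitor of this pair.

Compound 3 `O=C(N/N=C/c1ccncc1)c1cc2ccccc2oc1=O` has hydrogen in place of nitro on an aromatic carbon, and the change from compound 2 counts as hydrogen in place of nitro on an aromatic carbon. Going by the values given here, only one measured step bears on this change: a 3.2-fold higher number from compound 1 to compound 2 (0.51 log units; beyond the scatter), with nitro in place of bromo on an aromatic carbon. Among the compounds with values here, no compound with hydrogen at this place has been measured, so that step gives only indirect guidance. Going by a 3.2-fold higher number from compound 1 to compound 2 (0.51 log units; beyond the scatter), a modest step to a lower number is expected in this assay when nitro leaves, and it is not expected to be larger than that step. For compound 3, the expected step is a 2.1-fold lower number from compound 2 to compound 3 (0.32 log units; beyond the scatter). Compound 3 is estimated at 7500 nM, with an expected range from 2800 nM to 20000 nM.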

Compound 3, half-maximal inhibitory concentration: 17200 nM
The estimate for compound 3 lay 2.3-fold (0.36 log units) below the measured number, and the stated range covers the measured number.
By their numbers in this assay, from the lowest: compound 1; then compounds 2 and 3 (each within the scatter of the next).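

With a 1.1-fold higher number from compound 2 to compound 3 (0.04 log units; within the scatter), the change from nitro to hydrogen on this aromatic carbon has no readable effect in this assay, so these two groups cannot be told apart at this place on the shared core. The comparison with bromo gives a 3.5-fold higher number from compound 1 to compound 3 (0.55 log units; beyond the scatter), which places compound 1 apart from both compound 2 and compound 3 and changes how the earlier step between bromo and nitro reads: it now looks like something particular to bromo, rather than a penalty that comes with nitro. No measurement in hand offers an explanation for why bromo differs from the other two groups here.

The compounds shown leave open whether chloro or iodo at this place would stand with compound 1 or with compound 2 and compound 3, and where an amine or a methoxy group would fall. They also leave open whether the separation of bromo from hydrogen and nitro would persist if the part of the molecule attached through the hydrazone-like chain were replaced by a carboxylic acid or a longer chain.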